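Hydroxy to hydrogen on the amino acid side chain

The compounds below may be only part of what the source reports. "The series", "measured", "known", "first", "only" and "open" are said of these compounds alone.

Measured so far:
Compound 1, `NC(=O)CC[C@H](NC(=O)CN(c1ncnc2c1ncn2C1CCCCO1)C1CC1)C(=O)OCc1ccccc1`: 37.8%
Compound 2, `O=C(CN(c1nc(Cl)nc2[nH]cnc12)C1CC1)N[C@@H](CO)C(=O)O`: 43.9%

Both were tested in a functional assay on the whole organism (Tail, strain ICR) with Mus musculus as the target, in the tail flick test, with a stated time of 90 min, at a dose of 25 umol/kg by the oral route; a higher number here means a stronger effect of the compound at the dose given, a lower number a weaker effect. Compound 2 gives the higher of the two numbers, yet its gap to compound 1 lies within the usual scatter, so the two cannot be set in order on these data. Among the compounds with values here, compound 1 and compound 2 differ in several places at once, and no single-change step between them can be read off.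

Compound 3, `C[C@H](NC(=O)CN(c1nc(Cl)nc2[nH]cnc12)C1CC1)C(=O)O`, is not yet measured. It differs from compound 2 as follows: hydrogen in place of hydroxy on a saturated chain carbon, two bonds along the chain from an amide-type nitrogen and a carbonyl carbon

Nothing measured here isolates this change. The expectation is a step from compound 2 to compound 3 of a number 3.9 percentage points lower from compound 2 to compound 3 (within the scatter), that is, no movement beyond the scatter in either direction. Compound 3 is therefore estimated at 40%, with a range from 25% to 55%.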

Compound 3, a percentage reported as activity, at one dose (the size of the read-out at that dose, not a potency): 43.5%
Compound 3: middle estimate off by 3.5 percentage points, on the low side; measured number inside the range.
By their numbers in this assay, from the lowest: compounds 1, 3 and 2 (each within the scatter of the next).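

Within the data shown here, compound 2 and compound 3 form the first single-change pair, so one position can now be read on its own. In this assay, the exchange of hydroxymethyl for methyl gives a number 0.4 percentage points lower from compound 2 to compound 3 (within the scatter). At this one dose and time, the hydroxy on this saturated chain carbon, two bonds along the chain from an amide-type nitrogen and a carbonyl carbon, can therefore be replaced by hydrogen without a movement beyond the scatter; no measurement available bears on why this is so.

From the compounds shown here alone, whether an amine, a carboxylic acid or a longer chain at this position would also stay within the scatter remains open. Going by these compounds, one dose also gives the size of the read-out only, so any difference in potency between compound 2 and compound 3 remains open too.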